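Trimming the Side Chain on an Endothelin Receptor Ligand

A few compounds are considered here, and "the series" means these few. Any claim that something is new, unique, unknown or untested is made for them only; others in the source may bear on it.

For the measured compounds named here, in an assay on A7R5 cells for displacement of a labelled ligand from Endothelin-1 receptor (Rattus norvegicus) (on this read-out lower numbers stand for stronger inhibition and higher numbers for weaker inhibition), compound 2 `COc1cccc(Sc2c(NS(=O)(=O)c3ccc(C(C)(C)C)cc3)noc2CCCCC=O)c1` gives 1400 nM, the lowest of the two numbers measured so far. The other compound, compound 1 `Cc1onc(NS(=O)(=O)c2ccc(N)cc2)c1I`, gives 11000 nM in this assay, a higher number than compound 2, and the gap lies beyond the usual scatter. Compound 3 `COc1cccc(Sc2c(NS(=O)(=O)c3ccc(C(C)(C)C)cc3)noc2CO)c1` has not yet been measured. It differs from compound 2 in one place: hydroxy in place of 3-formylpropyl on a saturated chain carbon bound to an aromatic carbon. Going by the values given here, no measured step of this kind exists to lean on, so only a modest move toward weaker binding is expected, a 2.1-fold higher number from compound 2 to compound 3 (0.33 log units; beyond the scatter). Compound 3 is therefore estimated at 3000 nM, with a range from 800 nM to 12000 nM.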

Compound 3, half-maximal inhibitory concentration: 6200 nM
For compound 3 the middle estimate is 2.1-fold (0.32 log units) below the measured one, within the range that was stated.
By their numbers in this assay, from the lowest: compound 2; then compounds 3 and 1 (each within the scatter of the next).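

Replacing 4-formylbutyl with hydroxymethyl gives a 4.4-fold higher number from compound 2 to compound 3 (0.65 log units; beyond the scatter) in this assay. For the compounds shown here, this is the first evidence that this position affects binding, and that shortening the chain here costs strength rather than leaving it unchanged. Nothing available accounts for this shift.

The change removes chain length and the formyl end together and adds a hydroxy, so the compounds shown leave open which part matters. A plain pentyl chain, or a chain of the same length ending in a carboxylic acid or an amine, would help separate these parts.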